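The source may report more compounds than this note shows. Statements on the series, on what has been measured and on what is new or still open speak of the compounds shown alone.

The series shares the core of compound 1 `CC(C)N1CCn2nc(-c3ccccc3)cc2C1=O`, which differs from compound 2 `O=C1c2cc(-c3ccccc3)nn2CCN1Cc1ccc(Cl)nc1` and compound 3 `CCCCN1CCn2nc(-c3ccccc3)cc2C1=O` only at the amide-type nitrogen in the ring. In a functional assay on A549 cells (Homo sapiens) for inhibition, read by MTT assay, with a stated time of 48 h (a higher number here means a weaker inhibitor, a lower number a stronger inhibitor), compound 1 gives > 64000 nM, a limit of the assay rather than a number. Compound 2 gives > 64000 nM in this assay, again a limit. Compound 3 likewise gives > 64000 nM there, also a limit. For the measured compounds named here, because of the limit of > 64000 nM in this assay, at which 3 of the 3 values shown sit, none of the measured steps can be read: a step that the two limits leave unreadable from compound 1 to compound 2, a step that the two limits leave unreadable from compound 1 to compound 3 and a step that the two limits leave unreadable from compound 2 to compound 3 all stay without a size. Compound 4 `COc1ccc(-c2cc3n(n2)CCN(Cc2ccc(Cl)nc2)C3=O)cc1` is set apart from compound 2 by methoxy in place of hydrogen on an aromatic carbon. Going by the values given here, no measured step touches this position, and every step that exists is unreadable, so nothing in the data points to a direction. Compound 4 is therefore expected to give about 80000 nM in this assay, with a range from 20000 nM to 300000 nM. This estimate implies an expected step that the limit leaves unreadable from compound 2 to compound 4, most likely once more a limit rather than a number.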

Compound 4, half-maximal inhibitory concentration: > 64000 nM
Compound 4 was reported as a limit; the forecaster's own chance of this, stated with the estimate: 80%; the middle value does not contradict the limit.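

The step from compound 2 to compound 4, phenyl to 4-methoxyphenyl, cannot be read, and no size can be given for it: the limit of > 64000 nM in this assay, at which 4 of the 4 values shown sit.

The compounds shown leave open which change to the shared core, if any, would give a measurable number rather than a limit.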